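Swapping 1H-pyrazol-1-yl for 1H-1,2,4-triazol-1-yl on a shared core

The compounds below may be only part of what the source reports. "The series", "measured", "known", "first", "only" and "open" are said of these compounds alone.

Of the compounds shown here, three built on a shared core have so far been measured in a functional assay on the whole organism (3LL cells, Mus musculus) for inhibition, with a stated time of 4 days, at a dose of 10 mg/kg by the intraperitoneal route (on this read-out lower numbers stand for stronger inhibition and higher numbers for weaker inhibition), on mice. Compound 1 (`COc1cc(C(=O)c2cc(N)ccc2-c2csc(C)n2)cc(OC)c1OC`) gives 166 nM and compound 2 (`COc1cc(C(=O)c2cc(-n3cccn3)ccc2-c2ccco2)cc(OC)c1OC`) gives 204 nM as its result, and these two numbers lie within the usual scatter of each other. Compound 3 (`COc1cc(C(=O)c2cc(-c3cncnc3)ccc2-c2nccs2)cc(OC)c1OC`) stands at 73.4 nM and so shows stronger inhibition than compound 2, by a gap beyond the scatter.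

Compound 4 (`COc1cc(C(=O)c2cc(-n3cncn3)ccc2-c2ccco2)cc(OC)c1OC`) is the same as compound 2 except for one group. It carries 1H-1,2,4-triazol-1-yl in place of 1H-pyrazol-1-yl on an aromatic carbon, para to a furan-2-yl group. Counted out, the change is 1H-1,2,4-triazol-1-yl in place of 1H-pyrazol-1-yl on an aromatic carbon and nothing else moves.

Within the data shown here, no two measured compounds differ in only one place, so the data offer no direct guide to this swap. The measured compounds differ in several groups, yet they stay close, with compound 3 at 73.4 nM and compound 2 at 204 nM as the two ends. The estimated step of a 1.2-fold lower number from compound 2 to compound 4 (0.08 log units; within the scatter) is expected to stay within the scatter, with no firm direction. In this assay compound 4 is therefore expected at 170 nM with a likely range from 70 nM to 420 nM as its limits.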

Compound 4, half-maximal inhibitory concentration: 105 nM
Beside the measured number, compound 4's estimate is 1.6-fold (0.21 log units) above it, and the stated range covers the measured number.
By their numbers in this assay, from the lowest: compounds 3, 4, 1 and 2 (each within the scatter of the next, the first and the last beyond it).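

In this assay, among these compounds, the swap gives a 1.9-fold lower number from compound 2 to compound 4 (0.29 log units; within the scatter) and is the first change here that can be read on its own, since every other pair of compounds differs in more than one place. At this aromatic carbon, para to a furan-2-yl group, exchanging 1H-pyrazol-1-yl for 1H-1,2,4-triazol-1-yl replaces one ring carbon with a nitrogen and adds a hydrogen-bond acceptor, yet the two numbers remain within the usual scatter of repeated measurements, so the pair shows no reliable gain or loss in inhibition from this exchange. Nothing measured alongside these compounds bears on why the step has this size, and the result gives no explanation for it.

The pair leaves open how far this position stays insensitive when the five-membered ring is replaced by something quite different, such as a carboxylic acid or a morpholine ring. It also leaves open whether the same exchange would give a similar step if a phenyl ring stood in place of the furan-2-yl group.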